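The source may report more compounds than this note shows. Statements on the series, on what has been measured and on what is new or still open speak of the compounds shown alone.

Measured compounds:
- Compound 1 `COc1ccc(CNCCCNS(=O)(=O)c2cc(C(F)(F)F)cc(C(F)(F)F)c2)cc1OC`: 2800 nM
- Compound 2 `O=S(=O)(NCCCCCCNCc1ccc(Br)cc1)c1ccccc1F`: 13300 nM

Of the compounds shown here, two have so far been tested in a functional assay on MIA PaCa-2 cells (Homo sapiens) for inhibition, read by MTT assay, with a stated time of 72 h; a lower number here means a stronger inhibitor of growth, a higher number a weaker inhibitor of growth. Compound 1 gives 2800 nM in this assay, and compound 2 gives 13300 nM, which is the highest of the two numbers. Its nearest neighbour is compound 1, whose number is lower by a gap beyond the usual scatter; since the two structures differ in several places at once, nothing more than that comparison of values can be drawn from them.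

Compound 3 `O=S(=O)(NCCCCCCNCc1ccc(Br)cc1)c1ccccc1Cl` is the next compound. It differs from compound 2 in one place only: chloro in place of fluoro on an aromatic carbon of a six-membered aromatic ring of carbon only, ortho to a large group. For the measured compounds named here, no pair of measured compounds shows this change, so there is no measured step to lean on. The exchange of one halogen for another at the same position is expected to move the number only a little, and the step from compound 2 to compound 3 in this assay is estimated at a 1.3-fold lower number from compound 2 to compound 3 (0.12 log units; within the scatter), a shift that stays within the scatter. Compound 3 is therefore expected to give about 10000 nM, in the range 4000 nM to 25000 nM.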

Compound 3, concentration for 50% growth inhibition: 13700 nM
The estimate for compound 3 lay 1.4-fold (0.14 log units) below the measured number; the measured number falls inside the stated range.
By their numbers in this assay, from the lowest: compound 1; then compounds 2 and 3 (each within the scatter of the next).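

For the compounds shown here, the exchange of 2-fluorophenyl for 2-chlorophenyl gives the first step in this assay that can be read at a single place, and it comes to a 1.0-fold higher number from compound 2 to compound 3 (0.01 log units; within the scatter). At this position, on an aromatic carbon of a six-membered aromatic ring of carbon only and ortho to a large group, the two halogens therefore cannot be told apart in this read-out, something the earlier comparison, spanning several places at once, could not show. The compounds offer no measurement that would account for this result.

Going by these compounds alone, whether the position stays as indifferent to a group that is not a halogen, such as a nitrile, an amine or a carboxylic acid, remains open, since fluoro and chloro are the only groups seen there in a one-place comparison. Also open, from the compounds shown here alone, is how the number would respond to a change elsewhere in the structure of compound 2, such as a longer chain or an amine in place of the bromo group.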